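The source may report more compounds than this note shows. Statements on the series, on what has been measured and on what is new or still open speak of the compounds shown alone.

Compound 1 `Cc1nc(Nc2ccccc2)c2cc[nH]c2n1` has the highest number of the three measured compounds in a functional assay on the whole organism for inhibition, with Nicotiana tabacum as the target; on this read-out lower numbers stand for stronger inhibition and higher numbers for weaker inhibition: compound 1 gives 550000000 nM. Compound 2 `Cc1nc(Nc2ccc(Cl)cc2)c2cc[nH]c2n1` carries chloro on an aromatic carbon of the six-membered ring and gives 224000000 nM; compound 3 `Cc1nc(Nc2ccc(Br)cc2)c2cc[nH]c2n1` carries bromo on that carbon and gives 170000000 nM. The change from compound 1 to compound 4 `Cc1nc(Nc2ccc(N)cc2)c2cc[nH]c2n1` is amino in place of hydrogen on an aromatic carbon. The two measured steps that bear on it each put a halogen on that same aromatic carbon: a 2.5-fold lower number from compound 1 to compound 2 (0.39 log units; beyond the scatter) and a 3.2-fold lower number from compound 1 to compound 3 (0.51 log units; beyond the scatter), both modest and beyond the scatter, while a 1.3-fold lower number from compound 2 to compound 3 (0.12 log units; within the scatter). For the measured compounds named here, no measured compound shows how an amino group behaves at this place, so its direction is open; the halogen steps show only that a group on this carbon has so far lowered the number modestly. For compound 4 a small change is therefore expected, a 1.4-fold lower number from compound 1 to compound 4 (0.14 log units; within the scatter), with a wide range. Compound 4 is estimated at 400000000 nM, between 150000000 nM and 1100000000 nM.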

Compound 4, half-maximal inhibitory concentration: 195000000 nM
Beside the measured number, compound 4's estimate is 2.1-fold (0.31 log units) above it; low and high end bracket the measured number.
By their numbers in this assay, from the lowest: compounds 3, 4 and 2 (each within the scatter of the next); then compound 1.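

In this assay, for the compounds shown here, amino is the first group on this aromatic carbon that is not a halogen, and it also lowers the number, with a 2.8-fold lower number from compound 1 to compound 4 (0.45 log units; beyond the scatter). Amino cannot be told apart from either halogen, with a 1.1-fold higher number from compound 3 to compound 4 (0.06 log units; within the scatter) and a 1.1-fold lower number from compound 2 to compound 4 (0.06 log units; within the scatter), so three different groups at this place all give values within the scatter of each other. Nothing available explains why these groups give such similar results.

From the compounds shown here alone, it remains open whether a hydroxyl group, a methoxy group or a carboxylic acid on the same carbon would match these three groups or depart from them. Also open, going by these compounds, is whether a longer chain on the amino nitrogen, or any of these groups elsewhere on the six-membered ring, would move the number further.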